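Cytotoxicity notes on a shared-core series: two limits, one step

The source may hold more compounds than are shown below. What is called first, only, known or untested is meant among the compounds shown, and "the series" means these compounds.

compound 1 `COc1ccc(S(=O)(=O)c2cn(-c3ccc4c(c3)B(O)OC4)c3ccccc23)cc1` — > 10 ug/mL
compound 2 `Cc1ccccc1C(=O)c1ccn(-c2ccc3c(c2)B(O)OC3)c1` — > 10 ug/mL

In an ADME assay on L929 cells (Mus musculus) for cytotoxicity, read by resazurin assay, with a stated time of 72 h (on this read-out higher numbers stand for weaker inhibition and lower numbers for stronger inhibition), compound 1 gives > 10 ug/mL, which is a limit of the assay and not a number. In this assay compound 2 gives > 10 ug/mL, likewise only a limit. Both measured compounds therefore sit at the limit of > 10 ug/mL in this assay, at which 2 of the 2 values shown sit, so compound 2 stands at the limit and nowhere else on the numbers shown.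

Compound 3 `Cc1ccc(C(=O)c2ccn(-c3ccc4c(c3)B(O)OC4)c2)s1` is not yet measured; it differs from compound 2 by 5-methylthiophen-2-yl in place of 2-methylphenyl on a carbonyl carbon. Among the compounds with values here, no measured step between compounds exists here. The expected step that the limit leaves unreadable from compound 2 to compound 3 is none beyond the scatter. Compound 3 is estimated at 20 ug/mL, within 8 ug/mL to 50 ug/mL.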

Compound 3, half-maximal inhibitory concentration: > 10 ug/mL
Compound 3 gave a limit, no number (the forecaster's own chance of this, stated with the estimate: 80%); the middle value lies beyond the limit too.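

No step from compound 2 to compound 3 can be read, as each value is only a limit: the limit of > 10 ug/mL in this assay, at which 3 of the 3 values shown sit.

From the compounds shown here alone, whether 5-methylthiophen-2-yl in place of 2-methylphenyl on a carbonyl carbon shifts the read-out at all stays open.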